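One added ethoxy group on a weak growth inhibitor

The source may hold more compounds than are shown below. What is called first, only, known or untested is meant among the compounds shown, and "the series" means these compounds.

Going by the values given here, in a functional assay on MCF7 cells (Homo sapiens) for antiproliferative activity (a higher number here means a weaker inhibitor of growth, a lower number a stronger inhibitor of growth), compound 1 (`COc1ccc(-c2nc3cc(F)ccc3s2)cc1`) gives 490 nM and stands highest of the two numbers so far. Compound 2 (`COc1cc(-c2nc3cc(F)ccc3s2)cc(OC)c1OC`) gives 1.9 nM and carries more groups on that ring. Compound 3 (`CCOc1cc(-c2nc3cc(F)ccc3s2)ccc1OC`) has ethoxy in place of hydrogen on an aromatic carbon, ortho to a methoxy group and meta to a large group (ethoxy in place of hydrogen on an aromatic carbon). Among the compounds with values here, no single change has been measured yet, so compound 2 at 1.9 nM is the only guide, and it points downward. The expected step, a fall beyond the scatter, is a 20-fold lower number from compound 1 to compound 3 (1.29 log units; beyond the scatter) on this estimate. Compound 3 is estimated at 25 nM in this assay with a likely range from 2 nM to 250 nM as its bounds.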

Compound 3, concentration for 50% growth inhibition: 80 nM
Estimate against measurement, compound 3: 3.2-fold (0.51 log units) below, and the stated range covers the measured number.
By their numbers in this assay, from the lowest: compound 2; then compound 3; then compound 1.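

Putting ethoxy in place of hydrogen on this aromatic carbon, ortho to a methoxy group, is a single change, and in this assay it gives a 6.1-fold lower number from compound 1 to compound 3 (0.79 log units; beyond the scatter) as its result. Going by these compounds alone, this is the first reading of one change on this ring, and it shows that a group larger than hydrogen at this position goes with stronger growth inhibition, though the step is modest. No measurement here says why the step occurs.

From the compounds shown here alone, whether a longer propoxy chain or an amine on this same carbon would give a larger or smaller step stays open.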